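Swapping a fluorinated chain for a fluorophenyl on the amine

The compounds below may be only part of what the source reports. "The series", "measured", "known", "first", "only" and "open" are said of these compounds alone.

Compound 1 `CCCN(CCC(F)(F)F)Cc1c(C(F)(F)F)nc2n(-c3c(C)cc(C)cc3C)c(Cl)cn12` is the stronger of the two measured compounds in an assay on cells for displacement of a labelled ligand from corticotropin-releasing factor receptor 1 (Homo sapiens), with a stated time of 100 min; a lower number here means a stronger inhibitor, a higher number a weaker inhibitor: compound 1 gives 12 nM. Among the measured compounds shown here, compound 2 `Cc1cc(C)c(-n2c(Cl)cn3c(CN(CCC4CC4)CCC(F)(F)F)c(C(F)(F)F)nc23)c(C)c1` gives 110 nM in this assay, and the single measured step, a 9.2-fold higher number from compound 1 to compound 2 (0.96 log units; beyond the scatter), shows that replacing a group on a saturated chain carbon two bonds along the chain from an amine nitrogen costs a modest amount of binding. Compound 3 `CCCN(Cc1ccc(F)cc1)Cc1c(C(F)(F)F)nc2n(-c3c(C)cc(C)cc3C)c(Cl)cn12` has not yet been measured. It differs from compound 1 in the change (4-fluorophenyl in place of 2,2,2-trifluoroethyl on a saturated chain carbon bound to an amine nitrogen), so the whole chain on that side becomes 4-fluorobenzyl in place of 3,3,3-trifluoropropyl. For the measured compounds named here, no measured step bears directly on this swap; the step from compound 1 to compound 2 altered a different chain on the same kind of nitrogen and is only a loose guide. Because a 9.2-fold higher number from compound 1 to compound 2 (0.96 log units; beyond the scatter) showed that altering a chain there weakened binding, a weakening is expected here too, though the entering group is of a different kind and the step could as well be small. Compound 3 is estimated at 30 nM, with a range of 8 nM to 150 nM, which would mean an expected step of a 2.5-fold higher number from compound 1 to compound 3 (0.40 log units; beyond the scatter).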

Compound 3, inhibition constant: 350 nM
Compound 3: middle estimate off by 12-fold (1.07 log units), on the low side, and the stated range ends below it.
By their numbers in this assay, from the lowest: compound 1; then compound 2; then compound 3.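

In this assay, the exchange of 3,3,3-trifluoropropyl for 4-fluorobenzyl gives a 29-fold higher number from compound 1 to compound 3 (1.46 log units; beyond the scatter), so this chain on the amine nitrogen cannot be swapped for an aromatic ring without a large loss of binding. Among the compounds shown here, until now, the only measured change was on the other chain on that nitrogen, a 9.2-fold higher number from compound 1 to compound 2 (0.96 log units; beyond the scatter), so both chains have now been altered, and each change leaves a weaker binder than compound 1. Nothing measured here accounts for the loss on going to the aromatic ring.

The swap removes the 2,2,2-trifluoroethyl group and brings in both a six-membered aromatic ring and its fluorine in a single step, so these compounds cannot show which part of the change matters for binding. An unsubstituted benzyl group would test whether the ring fluorine plays any part, while a saturated ring such as cyclohexylmethyl or a longer chain such as 4,4,4-trifluorobutyl would show how this chain responds to changes that bring in no aromatic ring.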